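A Hydroxyphenyl Replacement in the Dichlorophenyl Series

The source may hold more compounds than are shown below. What is called first, only, known or untested is meant among the compounds shown, and "the series" means these compounds.

compound 1 `CN1CCN(c2nc(-c3ccc(Cl)c(Cl)c3)nc3[nH]cnc23)CC1`: > 80%
compound 2 `Clc1ccc(-c2nc(N3CCCCC3)c3nc[nH]c3n2)cc1Cl`: 24.1%
compound 3 `CN1CCN(c2nc(-c3ccc(Cl)c(C(F)(F)F)c3)nc3[nH]cnc23)CC1`: 52.4%
compound 4 `CN1CCN(c2nc(-c3cccc(O)c3)nc3[nH]cnc23)CC1`: not yet measured

In an assay on cells for displacement of a labelled ligand from adenosine receptor A1 (Homo sapiens), read by scintillation counting and radioligand binding, with a stated time of 60 min, tested at 10 uM (a lower number here means less inhibition, a higher number more inhibition at the concentration tested (going by the name of the read-out)), compound 1 gives > 80%, which is a limit of the assay rather than a number (the limit of > 80% in this assay, at which 1 of the 3 values shown sits). Compound 1 therefore stands only at a limit among the values shown. Compound 2 gives 24.1%, and compound 3 gives 52.4%. The step of a number at least 55.9 percentage points lower from compound 1 to compound 2 (beyond the scatter) alters a different part of the molecule. The step of a number at least 27.6 percentage points lower from compound 1 to compound 3 (beyond the scatter) alters a substituent of the 3,4-dichlorophenyl group, and the change to compound 4 removes that group entirely: 3-hydroxyphenyl in place of 3,4-dichlorophenyl on an aromatic carbon. The expected step is a number at least 45 percentage points lower from compound 1 to compound 4 (beyond the scatter), a drop beyond the scatter. Compound 4 is estimated at 35%, in a range from 8% to 70%.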

Compound 4, a percentage reported as inhibition, at one concentration (the size of the read-out at that concentration, not a potency): > 80%
Compound 4: only a limit was reported; the forecaster's own chance of this, stated with the estimate: 8%; at least 45 percentage points between middle value and limit.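

No step can be read between compound 1 and compound 4, because each stands at a limit of the assay rather than at a number: the limit of > 80% in this assay, at which 2 of the 4 values shown sit.

The compounds shown leave open whether compound 1 and compound 4 differ at all, and by how much.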